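Working notes: replacing 2,5-dimethylphenyl in compound 1

The source may hold more compounds than are shown below. What is called first, only, known or untested is meant among the compounds shown, and "the series" means these compounds.

compound 1 `Cc1ccc(C)c(N2CCN(C(=O)c3oc(C)nc3-c3ccccc3)CC2)c1` 1.4%
compound 2 `Cc1nc(-c2cccc(F)c2)c(C(=O)N2CCN(c3cc(Cl)cc(Cl)c3)CC2)o1` 40.7%
compound 3 `COc1cc(OC)cc(N2CCN(C(=O)c3oc(C)nc3-c3cccc(F)c3)CC2)c1` 11.6%

All three compounds were tested in an ADME assay on microsomes from liver (Mus musculus) for metabolic stability, read by LC-MS, with a stated time of 1 h, tested at 5 uM (on this read-out higher numbers stand for a more stable compound and lower numbers for a less stable compound), and compound 4 `COc1cc(OC)cc(N2CCN(C(=O)c3oc(C)nc3-c3ccccc3)CC2)c1` awaits its number. Compound 1 sits at 1.4% as the lowest of the three numbers, with compound 3 nearest at 11.6% and compound 2 furthest at 40.7% on the same scale, both gaps being beyond the scatter.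

Compound 4 has 3,5-dimethoxyphenyl in place of 2,5-dimethylphenyl on an amine nitrogen in a ring, and the change 3,5-dimethoxyphenyl in place of 2,5-dimethylphenyl on an amine nitrogen in a ring leaves the core of compound 1 as it is.

For the measured compounds named here, one measured step bears on it: a number 29.1 percentage points lower from compound 2 to compound 3 (beyond the scatter) for 3,5-dimethoxyphenyl in place of 3,5-dichlorophenyl, modest in size and beyond the scatter. That step starts from a different group, so it gives no direct size for this change. It does show that 3,5-dimethoxyphenyl can sit at a low number, and compound 3 with this group stands at 11.6% in the series. A small upward step, not clearly beyond the scatter, is therefore expected.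

The estimate means a number 7.6 percentage points higher from compound 1 to compound 4 (within the scatter) as an expected step. In this assay the estimated value for compound 4 is 9% and the expected range runs from 3% to 20% on this estimate.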

Compound 4, percent of the compound remaining: 0.7%
Estimate against measurement, compound 4: 8.3 percentage points above, and the stated range ends above it.
By their numbers in this assay, from the lowest: compounds 4 and 1 (each within the scatter of the next); then compound 3; then compound 2.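

In this assay, the step for 3,5-dimethoxyphenyl in place of 2,5-dimethylphenyl on an amine nitrogen in a ring, a number 0.7 percentage points lower from compound 1 to compound 4 (within the scatter), means that these two groups cannot be told apart on the core of compound 1. With 3,5-dimethoxyphenyl held fixed, the pair differing by hydrogen in place of fluoro on an aromatic carbon gives a number 10.9 percentage points lower from compound 3 to compound 4 (beyond the scatter), so the number seen with this group depends on the other place as well. The earlier reading of 3,5-dimethoxyphenyl, taken only with the fluoro present, therefore does not describe this group alone, and in this one pair the step at the aromatic carbon is the larger of the two new steps.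

As far as these compounds go, whether the fluoro step carries over to compounds bearing 2,5-dimethylphenyl or 3,5-dichlorophenyl remains open, as does how a chloro or a nitrile on that aromatic carbon would read. The compounds shown also come with no measurement that accounts for either step.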